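The source may report more compounds than this note shows. Statements on the series, on what has been measured and on what is new or still open speak of the compounds shown alone.

Measured so far:
compound 1 `Oc1ccc(-c2cc(-c3cccnc3)nc(-c3ccccc3Cl)c2)cc1` — "not determined" (no result reported)
compound 2 `Oc1ccc(-c2cc(-c3cccc(Cl)c3)nc(-c3ccccn3)c2)cc1` — 28200 nM
compound 3 `Oc1ccc(-c2cc(-c3cccc(Cl)c3)nc(-c3ccco3)c2)cc1` — 8020 nM

Among the compounds with values here, in a functional assay on HCT-15 cells (Homo sapiens) for cytotoxicity, read by CCK-8 assay and cell counting, with a stated time of 2 days (a lower number here means a stronger inhibitor, a higher number a weaker inhibitor), compound 3 gives the lowest of the two numbers; its nearest neighbour is compound 2, and the only measured step, a 3.5-fold lower number from compound 2 to compound 3 (0.55 log units; beyond the scatter), separates them. Compound 4 `Oc1ccc(-c2cc(-c3cccnc3)nc(-c3cccc(Cl)c3)c2)cc1` differs from compound 3 in one place: pyridin-3-yl in place of furan-2-yl on an aromatic carbon. Within the data shown here, no measured step covers this exact exchange; the step from compound 2 to compound 3 involves the same position but a different pair of groups, so it bears on compound 4 only loosely. Compound 3 is therefore expected to be a modest anchor, and compound 4 is expected to sit near it, with the step of a 1.9-fold higher number from compound 3 to compound 4 (0.27 log units; within the scatter) estimated. Compound 4 is estimated at 15000 nM, between 5000 nM and 45000 nM.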

Compound 4, half-maximal inhibitory concentration: 21300 nM
Compound 4: middle estimate off by 1.4-fold (0.15 log units), on the low side; the range from low to high includes it.
By their numbers in this assay, from the lowest: compound 3; then compounds 4 and 2 (each within the scatter of the next).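

At this position, next to the ring nitrogen, the change to pyridin-3-yl gives a 2.7-fold higher number from compound 3 to compound 4 (0.42 log units; beyond the scatter) and the change from pyridin-2-yl gives a 1.3-fold lower number from compound 2 to compound 4 (0.12 log units; within the scatter). The two pyridinyl groups thus stay within the scatter of each other whichever way their nitrogen lies, while furan-2-yl alone stands apart from both. Nothing measured here accounts for this.

On these data alone, it remains open whether a thiophen-2-yl group would match furan-2-yl, and whether an amine or a carboxylic acid at this position would retain any cytotoxicity.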